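Swapping nitro for sulfamoyl on the anilino ring

This account rests on a few compounds, and the source may have more. Where it says the series, first, only, none or still open, it means among the compounds named here.

Measured compounds:
compound 1, `Cn1nc(-c2ccnc(Nc3ccc([N+](=O)[O-])cc3)n2)c2ccccc21`, 8220 nM
compound 2, `Cn1nc(-c2ccnc(Nc3cccc([N+](=O)[O-])c3)n2)c2ccccc21`, 490 nM
compound 3, `Cn1nc(-c2ccnc(Nc3ccc(S(N)(=O)=O)cc3)n2)c2ccccc21`, 2280 nM

All three share one core and were tested in a functional assay on HCT-116 cells (Homo sapiens) for antiproliferative activity, read by MTT assay, with a stated time of 72 h; a lower number here means a stronger inhibitor of growth, a higher number a weaker inhibitor of growth. Compound 1 and compound 2 are built from the same atoms joined differently; the difference between the two cores is not broken down here. Compound 2 gives the lowest number of the three, so it is the strongest growth inhibitor in this set.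

Compound 3 differs from compound 1 by sulfamoyl in place of nitro on an aromatic carbon, and that change gave a 3.6-fold lower number from compound 1 to compound 3 (0.56 log units; beyond the scatter).

Compound 4, `Cn1nc(-c2ccnc(Nc3cccc(S(N)(=O)=O)c3)n2)c2ccccc21`, is not yet measured. It differs from compound 2 by sulfamoyl in place of nitro on an aromatic carbon. Going by the values given here, this is the same kind of change as the one from compound 1 to compound 3, but not the same: in compound 3 the sulfamoyl sits para to a large group, in compound 4 it sits meta to a large group. Because compound 3 improved on compound 1 by a 3.6-fold lower number from compound 1 to compound 3 (0.56 log units; beyond the scatter), a similar direction is expected here, though the change of place leaves the size uncertain; the expected step is a 2.0-fold lower number from compound 2 to compound 4 (0.29 log units; within the scatter). Compound 4 is therefore estimated at 250 nM, likely between 70 nM and 900 nM.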

Compound 4, concentration for 50% growth inhibition: 1980 nM
Estimate against measurement, compound 4: 7.9-fold (0.90 log units) below, and the stated range ends below it.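

In this assay, sulfamoyl in place of nitro gave a 4.0-fold higher number from compound 2 to compound 4 (0.61 log units; beyond the scatter), so on this core the swap weakened growth inhibition instead of strengthening it. The same swap went the opposite way on the other core, and the two steps differ by more than the scatter: the same change on two cores in this assay, a 3.6-fold lower number (0.56 log units; beyond the scatter) from compound 1 to compound 3 and a 4.0-fold higher number (0.61 log units; beyond the scatter) from compound 2 to compound 4, 15-fold (1.16 log units) apart, beyond the scatter of two such steps. This shows that, across these two pairs, neither the direction nor the size of the step can be carried from one core to the other, although two pairs cannot show why the direction reverses or predict what the swap would do on a further core.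

The compounds shown leave open whether other groups on the same aromatic carbon, such as an amine or a carboxylic acid, would behave more like nitro or more like sulfamoyl. They also leave open whether the reversal seen here would appear in cells other than those of this one growth test.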